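Shifting a Fluorine Around the Piperazine Aryl Ring

This account rests on a few compounds, and the source may have more. Where it says the series, first, only, none or still open, it means among the compounds named here.

Measured compounds and their values:
compound 1, `CCCc1nc(-c2ccccc2)c(CNCCN2CCN(c3ccccc3F)CC2)o1`: 46.5%
compound 2, `Cc1nc(-c2ccccc2)c(CNCCN2CCN(C(c3ccccc3)c3ccccc3)CC2)o1`: 57.3%
compound 3, `CCCc1nc(-c2ccccc2)c(CNCCCN2CCN(c3cccc(OC)c3)CC2)o1`: 36.4%

All three compounds were tested in an assay on HEK293 cells for inhibition of Voltage-dependent T-type calcium channel subunit alpha-1G (Homo sapiens), read by fluorescence, tested at 10 uM; on this read-out higher numbers stand for more inhibition at the one concentration tested (going by the name of the read-out) and lower numbers for less inhibition. They share a core built from the same oxazole, phenyl and piperazine pieces, and differ in what sits on the far ring nitrogen and in the linker length. Compound 1 stands second highest of the three numbers. Compound 3 lies below it by a gap that is beyond the usual scatter, and compound 2 lies above it by a gap that is also beyond the scatter. No pair among these three differs in only one place, so none of these gaps can be tied to a single structural change.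

Compound 4, `CCCc1nc(-c2ccccc2)c(CNCCN2CCN(c3ccc(F)cc3)CC2)o1`, has not yet been measured. It differs from compound 1 in one place only: 4-fluorophenyl in place of 2-fluorophenyl on an amine nitrogen in a ring. The same atoms are present, joined differently.

Within the data shown here, with no single-change step among the measured compounds to draw on, the step in this assay from compound 1 to compound 4 is expected to be small, with no clear direction and most likely not beyond the scatter. Compound 4 is therefore estimated at 45%, within a range from 30% to 60%, which means an expected step of a number 1.5 percentage points lower from compound 1 to compound 4 (within the scatter).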

Compound 4, a percentage reported as inhibition, at one concentration (the size of the read-out at that concentration, not a potency): 54.1%
The estimate for compound 4 lay 9.1 percentage points below the measured number, within the range that was stated.
By their numbers in this assay, from the lowest: compound 3; then compounds 1, 4 and 2 (each within the scatter of the next, the first and the last beyond it).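

In this assay, among these compounds, this is the first pair in the set that differs in one place only, so it gives the first direct reading of a single structural swap: with 4-fluorophenyl in place of 2-fluorophenyl on the amine nitrogen of the piperazine, the step is a number 7.6 percentage points higher from compound 1 to compound 4 (within the scatter). Both groups contain the same atoms, so this pair isolates where the fluorine sits on the aryl ring, and on this evidence the two placements cannot be told apart. No separate measurement is available to explain the number for either compound.

Because each compound was read at one concentration only, these numbers give the size of the inhibition at that concentration rather than a potency, and a real but modest difference between the two fluorine placements cannot be ruled in or out. Going by these compounds, it also remains open how this aryl ring responds to something other than a relocated fluorine, such as a chlorine atom, a nitrile or an amine in its place, or a plain phenyl ring carrying no fluorine at all.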